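The source may hold more compounds than are shown below. What is called first, only, known or untested is meant among the compounds shown, and "the series" means these compounds.

Compound 1 `C=CCn1ncc2c(C)nc(C)n2c1=O` and compound 2 `C=CCn1ncc2c(C)nc(CCC)n2c1=O` are built on one shared core. In a functional assay for inhibition, with Homo sapiens as the target (a higher number here means a weaker inhibitor, a lower number a stronger inhibitor), compound 2 gives 40000 nM, and compound 1 gives 73000 nM. The change between them, (hydrogen in place of ethyl on a saturated chain carbon bound to an aromatic carbon), produced a 1.8-fold higher number from compound 2 to compound 1 (0.26 log units; within the scatter). Compound 3 `CCCc1nnc(S)n2c(CCC)nc(C)c12` rests on another core; the difference between the two cores is not broken down here. In this assay compound 3 gives only a limit, > 48000 nM. Compound 4 `CCCc1nc(C)c2c(C)nnc(S)n12` has not yet been measured; it differs from compound 3 by hydrogen in place of ethyl on a saturated chain carbon bound to an aromatic carbon, the same change as that from compound 2 to compound 1. Since compound 3 sits at the limit of > 48000 nM in this assay, at which 1 of the 3 values shown sits, compound 4 is expected to return only a limit as well, with an estimated 80000 nM, a range from 40000 nM to 200000 nM, and an expected step that the limit leaves unreadable from compound 3 to compound 4.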

Compound 4, half-maximal inhibitory concentration: 45000 nM
Compound 4: the middle estimate sits 1.8-fold (0.25 log units) above what was measured, within the range that was stated.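

Compound 3 gives > 48000 nM in this assay, which is a limit of the assay and not a number. The new step therefore gives only a floor: an at least 1.0-fold lower number from compound 3 to compound 4 (0.02 log units; that floor lies within the scatter). The compounds show that the same change from propyl to methyl can be set beside itself on two cores, but they do not show whether its size carries over from one core to the other: the same change on two cores in this assay, a 1.8-fold higher number (0.26 log units; within the scatter) from compound 2 to compound 1 and an at least 1.0-fold lower number (0.02 log units; that floor lies within the scatter) from compound 3 to compound 4; the limit leaves it open whether they differ

The compounds shown leave open how a longer chain or an amine in place of the propyl would read in this assay. As far as these compounds go, how much the difference between the two cores itself contributes also remains open.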